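Methoxy Added to the Benzylsulfanyl Group of Compound 3

This account rests on a few compounds, and the source may have more. Where it says the series, first, only, none or still open, it means among the compounds named here.

Three compounds share one core. In a functional assay on BGC-823 cells (Homo sapiens) for inhibition, read by MTT assay, with a stated time of 72 h (a lower number here means a stronger inhibitor, a higher number a weaker inhibitor), compound 1 `CCCSc1nc2nc(C)cc(N3CC[C@@H](C)[C@@H](N(C)c4ncnc5[nH]ccc45)C3)n2n1` gives 51200 nM, compound 2 `Cc1cc(N2CC[C@@H](C)[C@@H](N(C)c3ncnc4[nH]ccc34)C2)n2nc(SCc3ccccc3Br)nc2n1` gives 81100 nM, and compound 3 `Cc1cc(N2CC[C@@H](C)[C@@H](N(C)c3ncnc4[nH]ccc34)C2)n2nc(SCc3ccccc3)nc2n1` gives 14400 nM, the lowest of the three numbers, separated from the others by the steps of a 3.6-fold lower number from compound 1 to compound 3 (0.55 log units; beyond the scatter) and a 5.6-fold lower number from compound 2 to compound 3 (0.75 log units; beyond the scatter), both beyond the scatter. Compound 4 `COc1ccc(CSc2nc3nc(C)cc(N4CC[C@@H](C)[C@@H](N(C)c5ncnc6[nH]ccc56)C4)n3n2)cc1` differs from compound 3 by methoxy in place of hydrogen on an aromatic carbon. For the measured compounds named here, the only earlier change on that aromatic ring, a 5.6-fold lower number from compound 2 to compound 3 (0.75 log units; beyond the scatter), removed a bromo group and lowered the number; the present change adds a group, so a modest step toward a higher number is expected, a 1.5-fold higher number from compound 3 to compound 4 (0.18 log units; within the scatter). Compound 4 is therefore estimated at 22000 nM, within a range from 7000 nM to 65000 nM.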

Compound 4, half-maximal inhibitory concentration: 69900 nM
For compound 4 the middle estimate is 3.2-fold (0.50 log units) below the measured one; measured number above the stated range.
By their numbers in this assay, from the lowest: compound 3; then compounds 1, 4 and 2 (each within the scatter of the next).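

Compound 3 now stands apart on both sides of its ring: a 4.9-fold higher number from compound 3 to compound 4 (0.69 log units; beyond the scatter) shows that a group para to a large group, like the bromo group of compound 2, comes with a higher number than the bare benzyl. With a 1.2-fold lower number from compound 2 to compound 4 (0.06 log units; within the scatter) and a 1.4-fold higher number from compound 1 to compound 4 (0.14 log units; within the scatter) both within the scatter, 4-methoxybenzyl cannot be told from 2-bromobenzyl or from the propyl chain of compound 1. No measurement given here explains this. As far as these compounds go, whether a fluoro, hydroxyl or amine group at this carbon would behave like methoxy remains open, as does methoxy at other ring carbons.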